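Replacing the piperazine of compound 1: working notes

The source may report more compounds than this note shows. Statements on the series, on what has been measured and on what is new or still open speak of the compounds shown alone.

Values in an ADME assay on microsomes from liver (Homo sapiens) for metabolic stability, read by LC-MS, with a stated time of 10 min (a lower number here means that less of the compound is left, a higher number that more of the compound is left), for three compounds
compound 1 `CC(C)N1CCN(c2cccc3c2C[C@H](CN(C)[C@H]2CCCc4cccnc42)NC3)CC1` gives 56.6%
compound 2 `CN(C[C@H]1Cc2c(cccc2N2CCN(Cc3ccccn3)CC2)CN1)[C@H]1CCCc2cccnc21` gives 4.2%
compound 3 `CN(C[C@H]1Cc2c(cccc2N2CCN(c3ncccn3)CC2)CN1)[C@H]1CCCc2cccnc21` gives 35.5%

Compound 1 stands highest of the three, and both steps away from it lie beyond the scatter. Compound 4 `CN(C[C@H]1Cc2c(cccc2N2C[C@@H]3C[C@H]2CN3)CN1)[C@H]1CCCc2cccnc21` shares the core of compound 1 and differs on an aromatic carbon (a group of 7 heavy atoms (5 carbon, 2 nitrogen; 2 five-membered non-aromatic rings with 1 hetero atom each) in place of a group of 9 heavy atoms (7 carbon, 2 nitrogen; one six-membered non-aromatic ring with 2 hetero atoms), on an aromatic carbon). Among the compounds with values here, two measured steps bear on this only in part: the large a number 52.4 percentage points lower from compound 1 to compound 2 (beyond the scatter) and the modest a number 21.1 percentage points lower from compound 1 to compound 3 (beyond the scatter) each keep the six-membered ring and change only the group on its nitrogen. Neither replaces the ring itself, so neither sets a firm direction. The expected change is a number 3.4 percentage points higher from compound 1 to compound 4 (within the scatter) and it remains quite uncertain. In this assay compound 4 is estimated at 60% (range 35% to 85%)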

Compound 4, percent of the compound remaining: 100%
The estimate for compound 4 lay 40 percentage points below the measured number; measured number outside the range, above it.
By their numbers in this assay, from the lowest: compound 2; then compound 3; then compound 1; then compound 4.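

Exchanging the ring itself on this aromatic carbon, rather than only the group on the piperazine nitrogen, gives a number 43.4 percentage points higher from compound 1 to compound 4 (beyond the scatter) in this assay and is the only change shown that moves the number up from compound 1. The entering group differs in both ring system and nitrogen substitution, carrying 1 hydrogen-bond donor where 4-isopropylpiperazin-1-yl has none. No measurement here accounts for the step. Going by these compounds, the separate contributions of the ring change and the loss of isopropyl remain open. A plain piperazin-1-yl, or an isopropyl on the free nitrogen of the entering group, would separate them.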